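Swapping the amide substituent on a fluorinated scaffold

A few compounds are considered here, and "the series" means these few. Any claim that something is new, unique, unknown or untested is made for them only; others in the source may bear on it.

Of the compounds shown here, three have so far been tested in a functional assay on the whole organism with Rattus norvegicus as the target, at a dose of 20 mg/kg by the oral route; a higher number here means more inhibition at the dose given (going by the name of the read-out), a lower number less inhibition. Compound 3 `O=C(/C=C1\CCc2ccc(F)cc21)NCC1CC1` gives 21%, which places it second of the three. Compound 2 `NC(=O)/C=C1\CCc2c(F)cccc21` gives 34%, a higher number that lies beyond the usual scatter, while compound 1 `Cc1cccc2c1CC/C2=C\C(=O)NC1CC1` gives 7%, a lower number that also lies beyond the scatter. No two of these compounds differ in only one place, so none of the gaps can be tied to a single structural change.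

The next compound, compound 4 `O=C(/C=C1\CCc2ccc(F)cc21)N1CCCC1`, differs from compound 3 in one place: pyrrolidin-1-yl in place of (cyclopropylmethyl)amino on a carbonyl carbon. The group that leaves carries one hydrogen-bond donor and a three-membered ring, the group that enters carries no donor and a five-membered ring containing the nitrogen. Within the data shown here, nothing among the measured compounds shows what such a swap does in this assay, so the step from compound 3 to compound 4 is expected to be small, most likely a modest fall, and quite possibly within the scatter: a number 6 percentage points lower from compound 3 to compound 4 (within the scatter). Compound 4 is therefore expected to give about 15%, with a plausible range from 0% to 35%.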

Compound 4, a percentage reported as inhibition, in the whole organism at one dose (the size of the read-out at that dose, not a potency): 18%
Compound 4: the middle estimate sits 3 percentage points below what was measured, within the range that was stated.
By their numbers in this assay, from the lowest: compound 1; then compounds 4 and 3 (each within the scatter of the next); then compound 2.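

In this assay, putting pyrrolidin-1-yl in place of (cyclopropylmethyl)amino on the carbonyl carbon gives a number 3 percentage points lower from compound 3 to compound 4 (within the scatter). Among these compounds, this is the first step here that can be tied to a single structural change. It shows that at this place, a swap that removes the amide hydrogen, the one hydrogen-bond donor of the leaving group, and brings the nitrogen into a five-membered ring does not separate the two compounds at this dose, and nothing available gives a reason for that.

Going by these compounds, it remains open whether a morpholine ring or a longer chain such as butylamino on the same carbonyl carbon would move the number beyond the scatter. Also open, on these data alone, is whether the same swap would read alike on a core carrying the fluorine elsewhere.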